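Shortening the Ketone Chain: From Compound 2 to Compound 3

The compounds below may be only part of what the source reports. "The series", "measured", "known", "first", "only" and "open" are said of these compounds alone.

Of the compounds shown here, two with a shared core have been measured in an assay on HEK293 cells for positive allosteric modulation of metabotropic glutamate receptor 2 (Rattus norvegicus), read by thallium flux, with a stated time of 2.5 min; on this read-out lower numbers stand for an effect already at smaller amounts and higher numbers for an effect only at larger amounts of compound. Compound 1 `COc1cc(C(=O)O)ccc1OCCCCOc1ccc(C(=O)CC(C)C)c(O)c1C` gives 40 nM. Compound 2 `COc1ccc(C(=O)O)cc1OCCCCOc1ccc(C(=O)CC(C)C)c(O)c1C` gives 155 nM in this assay. Of these two numbers, compound 2 stands at the higher one, and its gap to compound 1 lies beyond the scatter, so compound 2 is the weaker of the pair on this read-out.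

Compound 3 `CCCC(=O)c1ccc(OCCCCOc2cc(C(=O)O)ccc2OC)c(C)c1O` has not yet been measured. Set against compound 2, the change is hydrogen in place of methyl on a saturated chain carbon bound to two saturated chain carbons. Read one bond further out, the isobutylcarbonyl becomes a propylcarbonyl. Among the compounds with values here, no measured pair shows this change, so the size of its effect on the read-out is not known from these data. The change removes one small piece of a saturated chain and nothing else, so the expected step in this assay is a 1.6-fold higher number from compound 2 to compound 3 (0.21 log units; within the scatter), small, toward a somewhat higher number or none beyond the scatter. Compound 3 is therefore estimated at 250 nM, with a range from 100 nM to 700 nM.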

Compound 3, half-maximal effective concentration: 103 nM
Compound 3: the middle estimate sits 2.4-fold (0.39 log units) above what was measured, and the stated range covers the measured number.
By their numbers in this assay, from the lowest: compound 1; then compounds 3 and 2 (each within the scatter of the next).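

In this assay, within the data shown here, the loss of one methyl, which turns the isobutylcarbonyl into a propylcarbonyl, gives a 1.5-fold lower number from compound 2 to compound 3 (0.18 log units; within the scatter) and so provides the first measured pair that differs at this saturated chain carbon. The methyl branch at this place is therefore not needed to hold the read-out of compound 2, since the unbranched propyl chain stays within the usual scatter of the isobutyl chain. Nothing available here accounts for this result, so it stands as an observation without an explanation.

This single pair does not show how much more change the chain can take, such as a longer chain, a cyclopropyl group or an ether oxygen in place of a chain carbon. It also leaves open whether the same swap of isobutylcarbonyl to propylcarbonyl would give a similarly small step on compound 1, which carries the same ketone chain on a differently substituted benzoic acid end.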